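Swapping the Amine on a Dithiocarbamate Chromone Series

The source may hold more compounds than are shown below. What is called first, only, known or untested is meant among the compounds shown, and "the series" means these compounds.

Measured compounds:
- compound 1, `CCOC(=O)c1cc(=O)c2cc(CSC(=S)N(C(C)C)C(C)C)ccc2o1`: 15900 nM
- compound 2, `O=c1cc(CSC(=S)N2CCCC2)oc2ccccc12`: 9100 nM
- compound 3, `CC(C)N(C(=S)SCc1oc2ccccc2c(=O)c1Cl)C(C)C`: 20000 nM

In a functional assay on HEp-2 cells (Homo sapiens) for antiproliferative activity, read by MTT assay, with a stated time of 72 h (a lower number here means a stronger inhibitor, a higher number a weaker inhibitor), compound 1 gives 15900 nM. Among the three numbers, the nearest to compound 1 is that of compound 3, and the furthest is that of compound 2; both gaps lie within the usual scatter of this assay, so the three compounds cannot be told apart on these data. Each carries the same dithiocarbamate sulfur-linked arm on a shared core, and they differ only in the amine and in the substituents on the core.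

Compound 4, `CCOC(=O)c1cc(=O)c2cc(CSC(=S)N3CCCCC3)ccc2o1`, has not yet been measured. Compared with compound 1 the change is piperidin-1-yl in place of diisopropylamino on a thiocarbonyl carbon. Among the measured compounds shown here, nothing among the measured pairs isolates this change; compound 2 carries a cyclic amine but also differs on the core. The step in this assay from compound 1 to compound 4 is therefore expected to be small, a 1.2-fold lower number from compound 1 to compound 4 (0.09 log units; within the scatter), in no clear direction beyond the scatter. For compound 4 the expected value is 13000 nM, with a range from 5000 nM to 35000 nM.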

Compound 4, half-maximal inhibitory concentration: 3400 nM
Beside the measured number, compound 4's estimate is 3.8-fold (0.58 log units) above it; the measured number lies below the stated range.
By their numbers in this assay, from the lowest: compound 4; then compounds 2, 1 and 3 (each within the scatter of the next, the first and the last beyond it).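

In this assay, the amine on the thiocarbonyl carbon proves to matter: with the rest of the structure held fixed, piperidin-1-yl in place of diisopropylamino gives a 4.7-fold lower number from compound 1 to compound 4 (0.67 log units; beyond the scatter). The earlier compounds shown here could not show this, as compound 2 and compound 3 each differ from compound 1 on the core, so none of them isolated the amine. No measurement at hand explains why the number moves at this place.

Among the compounds shown here, whether the same swap would give a similar step on another core stays open, as this single pair is the only example. Also open, on these data alone, is what other amines on the thiocarbonyl carbon would give here, such as morpholin-4-yl, with an oxygen in its ring, or open-chain diethylamino.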